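The compounds below may be only part of what the source reports. "The series", "measured", "known", "first", "only" and "open" are said of these compounds alone.

Measured compounds:
- compound 1 `Cc1ccccc1Cc1ccc(N2CCC[C@H]2CC(=O)O)cc1`: in a functional assay on cells for agonist activity at Free fatty acid receptor 1 (Mus musculus), read by FLIPR and calcium flux, with a stated time of 100 s (on this read-out higher numbers stand for an effect only at larger amounts of compound and lower numbers for an effect already at smaller amounts), compound 1 gives > 33000 nM, which is a limit of the assay and not a number.
- compound 2 `COc1ccc(Oc2ccc(N3CCC[C@H]3CC(=O)O)cc2)cc1`: in this assay compound 2 gives > 33000 nM, again a limit of the assay.

Both values are limits, so no ordering of the two is possible; they share (the limit of > 33000 nM in this assay, at which 2 of the 2 values shown sit). Compound 1 therefore stands at the limit, with no measured effect at any amount tested. Compound 3 `Cc1ccccc1Cc1ccc(N2CC[C@H](C)[C@H]2CC(=O)O)cc1` differs from compound 1 by methyl in place of hydrogen on a saturated ring carbon, in words methyl in place of hydrogen on a saturated ring carbon. For the measured compounds named here, no step between measured compounds is known, so there is no measured guide for this change. Starting from a limit, the expectation is that the change from compound 1 to compound 3 gives no step beyond the scatter, a step that the limit leaves unreadable from compound 1 to compound 3, and that compound 3 most likely again reaches only a limit. Compound 3 is therefore estimated at 40000 nM, between 10000 nM and 200000 nM.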

Compound 3, half-maximal effective concentration: 1900 nM
Compound 3: middle estimate off by 21-fold (1.32 log units), on the high side; measured number below the stated range.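

In this assay a single methyl on a saturated ring carbon brings an at least 17-fold lower number from compound 1 to compound 3 (1.23 log units; beyond the scatter) and so gives the first real number among these compounds. This shows that the position, two ring bonds from the ring nitrogen and next to the ring atom that bears the carboxymethyl group, is not indifferent to substitution, and that even one added carbon can decide whether an effect is seen at all. The true size of the step cannot be read, because compound 1 stands at a limit of the assay: the limit of > 33000 nM in this assay, at which 2 of the 3 values shown sit.

The compounds shown leave open whether a larger ethyl group, or a hydroxyl group, at this carbon would go further or lose the gain. They also leave open whether the same methyl would help on the core of compound 2, which also stands at a limit.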